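From 1H-indazol-7-yl to 1H-benzimidazol-6-yl on a shared core

The source may hold more compounds than are shown below. What is called first, only, known or untested is meant among the compounds shown, and "the series" means these compounds.

In a physicochemical assay for lipophilicity, at pH 7.4 (on this read-out lower numbers stand for lower lipophilicity and higher numbers for higher lipophilicity), compound 3 (`CNC(=O)c1cc(C(=O)NC2CC2)cn(Cc2cccc3cn[nH]c23)c1=O`) gives 2.2 and stands lowest of the three measured, with compound 2 (`CNC(=O)c1cc(C(=O)NC2CC2)cn(Cc2cccc3[nH]ccc23)c1=O`) at 2.9 and compound 1 (`CNC(=O)c1cc(C(=O)NC2CC2)cn(Cc2cccc(F)c2)c1=O`) at 3.2 on the same scale. Compound 4 (`CNC(=O)c1cc(C(=O)NC2CC2)cn(Cc2ccc3nc[nH]c3c2)c1=O`) carries 1H-benzimidazol-6-yl in place of 1H-indazol-7-yl on a saturated chain carbon bound to an aromatic nitrogen. Changing this group has already moved the number: a number 0.70 log units lower from compound 2 to compound 3 (beyond the scatter) and a number 1.00 log units lower from compound 1 to compound 3 (beyond the scatter) were modest, while a number 0.30 log units lower from compound 1 to compound 2 (within the scatter) stayed small. Within the data shown here, no measured step shows this exact swap, so the downward direction is a judgement. The expected change is a number 0.40 log units lower from compound 3 to compound 4 (beyond the scatter) on this reasoning. The estimate for compound 4 is 1.8 with 1.2 to 2.4 as its expected range.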

Compound 4, distribution coefficient: 1.2
The estimate for compound 4 lay 0.60 log units above the measured number; low and high end bracket the measured number.
By their numbers in this assay, from the lowest: compound 4; then compound 3; then compounds 2 and 1 (each within the scatter of the next).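

Compound 3 and compound 4 have the same atoms and the same counted features, yet this assay gives a number 1.00 log units lower from compound 3 to compound 4 (beyond the scatter), so the arrangement of atoms within this group alone can shift the number beyond the scatter. The larger steps, a number 1.70 log units lower from compound 2 to compound 4 (beyond the scatter) and a number 2.00 log units lower from compound 1 to compound 4 (beyond the scatter), make 1H-benzimidazol-6-yl the lowest-reading of the four groups at this place. Nothing shown here explains why these two arrangements differ. Still open, going by these compounds, is how a group carrying an amine or a carboxylic acid would read at this place.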